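The compounds below may be only part of what the source reports. "The series", "measured", "known", "first", "only" and "open" are said of these compounds alone.

Of the compounds shown here, three have been measured in an ADME assay on cells (Mus musculus, strain Balb/c) for cytotoxicity, read by MTT assay, with a stated time of 48 h; on this read-out lower numbers stand for higher toxicity in this test and higher numbers for lower toxicity in this test. Compound 1 `COc1ccc(C(/C=C/c2ccc(Cl)cc2)=N/O)cc1` gives 291000 nM. Compound 2 `COc1ccc(C(/C=C/c2ccc(Cl)cc2Cl)=N/O)cc1` carries the change chloro in place of hydrogen on an aromatic carbon and gives 25000 nM, a step of a 12-fold lower number from compound 1 to compound 2 (1.07 log units; beyond the scatter). Compound 3 `O/N=C(\C=C\c1ccc(Cl)cc1)c1ccc(Br)cc1` differs from compound 1 in its core by bromo in place of methoxy on an aromatic carbon. Compound 3 gives 24700 nM, a step of a 12-fold lower number from compound 1 to compound 3 (1.07 log units; beyond the scatter); its value and that of compound 2 lie within the scatter of each other. Compound 4 `O/N=C(\C=C\c1ccc(Cl)c(Cl)c1)c1ccc(Br)cc1` is not yet measured; it differs from compound 3 by chloro in place of hydrogen on an aromatic carbon, the same kind of change as that from compound 1 to compound 2, though the surroundings differ: in compound 4 the entering chloro is ortho to a chloro group and meta to a large group, whereas in compound 2 it is ortho to a large group and meta to a chloro group. In this assay a step of a 2.7-fold lower number from compound 3 to compound 4 (0.44 log units; beyond the scatter) is expected, smaller than a 12-fold lower number from compound 1 to compound 2 (1.07 log units; beyond the scatter) because compound 3 already stands at 24700 nM. Compound 4 is therefore estimated at 9000 nM, with a likely range from 3500 nM to 25000 nM.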

Compound 4, half-maximal cytotoxic concentration: < 5000 nM
Compound 4: no number, only a limit; the forecaster's own chance of this, stated with the estimate: 5%; middle value at least 1.8-fold (0.25 log units) away from the limit.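

In this assay, chloro in place of hydrogen on an aromatic carbon again goes with a lower number on the second core, with an at least 4.9-fold lower number from compound 3 to compound 4 (0.69 log units; beyond the scatter). Compound 4 gives < 5000 nM, which is a limit of the assay and not a number. The direction of the change thus holds on the core of compound 1 and the core of compound 3, but these two cores alone show no general rule, and the size of the step cannot be compared between them: the same change on two cores in this assay, a 12-fold lower number (1.07 log units; beyond the scatter) from compound 1 to compound 2 and an at least 4.9-fold lower number (0.69 log units; beyond the scatter) from compound 3 to compound 4; the limit leaves it open whether they differ

The compounds shown leave open whether the entering chloro would give a like step on the core of compound 3 at the place it holds in compound 2. They also leave open how an amine or a carboxylic acid would act in place of this chloro.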